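This account rests on a few compounds, and the source may have more. Where it says the series, first, only, none or still open, it means among the compounds named here.

Three compounds share one core and differ only in the aromatic ring on one side. Compound 1 `CN1C/C(=C\c2ccc(C#N)cc2)C(=O)/C(=C/c2ccccc2F)C1` gives 810 nM in a functional assay on THP-1 cells (Homo sapiens) for cytotoxicity, read by MTT assay, with a stated time of 24 h; a higher number here means a weaker inhibitor, a lower number a stronger inhibitor; compound 3 `CN1C/C(=C\c2ccc(C#N)cc2)C(=O)/C(=C/c2ccc(Cl)cc2Cl)C1` gives 1910 nM; and compound 2 `CN1C/C(=C\c2ccc(F)cc2)C(=O)/C(=C/c2ccc(C#N)cc2)C1` gives 5030 nM, the highest of the three, so it is the weakest inhibitor here, with a 6.2-fold higher number from compound 1 to compound 2 (0.79 log units; beyond the scatter) and a 2.6-fold lower number from compound 2 to compound 3 (0.42 log units; beyond the scatter). Compound 4 `CN1C/C(=C\c2ccc(C#N)cc2)C(=O)/C(=C/c2ccc(C(F)(F)F)cc2)C1` is not yet measured; it differs from compound 2 by trifluoromethyl in place of fluoro on an aromatic carbon. The nearest guide is the step of a 2.6-fold lower number from compound 2 to compound 3 (0.42 log units; beyond the scatter), where a larger substituent pattern on that ring gave a lower number, while a 2.4-fold higher number from compound 1 to compound 3 (0.37 log units; beyond the scatter) shows a modest move the other way. A modest lowering is therefore expected, a 2.0-fold lower number from compound 2 to compound 4 (0.30 log units; within the scatter), so compound 4 is estimated at 2500 nM, most likely between 1000 nM and 6000 nM.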

Compound 4, half-maximal inhibitory concentration: 1430 nM
Estimate against measurement, compound 4: 1.7-fold (0.24 log units) above; low and high end bracket the measured number.
By their numbers in this assay, from the lowest: compounds 1, 4 and 3 (each within the scatter of the next, the first and the last beyond it); then compound 2.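

On an aromatic carbon para to a large group, a single swap of one group for another moves the number: trifluoromethyl in place of fluoro gives a 3.5-fold lower number from compound 2 to compound 4 (0.55 log units; beyond the scatter). Among these compounds, the earlier steps changed the ring's substitution pattern, so this is the first to isolate one group at this place, and it shows that trifluoromethyl, the group with more heavy atoms, does not raise the number. No measurement here explains this step. On these data alone, an amine, a carboxylic acid or a longer chain at this place remains open, so no trend across groups can be drawn from this single step.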